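The source may report more compounds than this note shows. Statements on the series, on what has been measured and on what is new or still open speak of the compounds shown alone.

Compound 1 `COc1ccc(-c2ccc(-c3ccc(-c4nc5ccccc5[nH]4)cc3)cc2)cc1` and compound 2 `COc1ccc(-c2ccc(-c3ccc(-c4nc5ccccc5[nH]4)cc3)cc2)cc1OC` share one core and differ in a single place. In a functional assay on COLO 205 cells (Homo sapiens) for inhibition, read by sulforhodamine B assay (a higher number here means a weaker inhibitor of growth, a lower number a stronger inhibitor of growth), compound 1 gives 45200 nM, and compound 2 gives 41200 nM. The step of a 1.1-fold lower number from compound 1 to compound 2 (0.04 log units; within the scatter) brought a methoxy in place of hydrogen on an aromatic carbon. On these two numbers compound 2 holds the lower of the two, but its gap to compound 1 lies within the scatter, so the two cannot be told apart.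

Compound 3 `COc1ccc(-c2ccc(-c3ccc(-c4nc5c(O)cccc5[nH]4)cc3)cc2)cc1OC` has not yet been measured in this assay. It differs from compound 2 by hydroxy in place of hydrogen on an aromatic carbon; cut one bond further out, the change reads 1H-benzimidazol-2-yl to 4-hydroxy-1H-benzimidazol-2-yl. No measured step touches this part of the core: the only step shown, from compound 1 to compound 2, concerns a methoxy rather than a hydroxy and stayed within the scatter. With nothing to point either way, the step of a 1.2-fold lower number from compound 2 to compound 3 (0.07 log units; within the scatter) is expected to lie within the scatter. Compound 3 is therefore estimated at 35000 nM, in the range 14000 nM to 85000 nM.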

Compound 3, concentration for 50% growth inhibition: 1320 nM
For compound 3 the middle estimate is 27-fold (1.42 log units) above the measured one; the whole stated range lies above it.
By their numbers in this assay, from the lowest: compound 3; then compounds 2 and 1 (each within the scatter of the next).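

In this assay the change from 1H-benzimidazol-2-yl to 4-hydroxy-1H-benzimidazol-2-yl gives a 31-fold lower number from compound 2 to compound 3 (1.49 log units; beyond the scatter), so this carbon of the six-membered ring, part of the fused system, proves highly sensitive to one added hydroxy. The earlier step, a 1.1-fold lower number from compound 1 to compound 2 (0.04 log units; within the scatter), put a methoxy elsewhere on the molecule and stayed within the scatter, so only now does a single change in one place move the number well beyond it. The data shown offer nothing that accounts for the size of this step.

Whether the effect belongs to the hydroxy itself or would also appear with a methoxy, an amine or a carboxylic acid on the same carbon stays open, as only hydrogen and hydroxy are shown there. Also open, on these data alone, are whether a hydroxy on another carbon of that ring would give a similar step, and whether the same hydroxy would act alike on the core of compound 1, which carries one methoxy fewer than compound 2.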